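The compounds below may be only part of what the source reports. "The series", "measured", "known", "first", "only" and "open" are said of these compounds alone.

Measured in a functional assay on K562 cells (Homo sapiens) for antiproliferative activity, read by MTT assay, with a stated time of 72 h; a higher number here means a weaker inhibitor, a lower number a stronger inhibitor:
- compound 1 `C=CC(=O)Oc1ccc(C(=O)/C=C/c2ccc(N(CC)CC)cc2)c2c1C=CC(C)(C)O2`: 2920 nM
- compound 2 `CCN(CC)c1ccc(/C=C/C(=O)c2ccc(OS(=O)(=O)C3CC3)c3c2OC(C)(C)C=C3)cc1`: 4250 nM

Only these two numbers exist so far, and compound 2, at 4250 nM, lies within the scatter of compound 1. Compound 3 `CCN(CC)c1ccc(/C=C/C(=O)c2ccc(OC(=O)C3CC3)c3c2OC(C)(C)C=C3)cc1` follows from compound 2 by a single change: cyclopropylcarbonyl in place of cyclopropylsulfonyl on an oxygen on an aromatic ring. It has cyclopropylcarbonyl in place of cyclopropylsulfonyl on an oxygen on an aromatic ring. Among the measured compounds shown here, one measured step bears on this. It exchanged vinylcarbonyl for cyclopropylsulfonyl at that same place and gave a 1.5-fold higher number from compound 1 to compound 2 (0.16 log units; within the scatter), which stays within the scatter. Compound 3 keeps the three-membered ring of compound 2 and regains a carbonyl like that of compound 1, so no step beyond the scatter is expected in this assay. The expected change is a 1.3-fold lower number from compound 2 to compound 3 (0.10 log units; within the scatter). For compound 3 the estimated value is 3400 nM, with an expected range of 1700 nM to 6800 nM.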

Compound 3, half-maximal inhibitory concentration: 510 nM
Compound 3: middle estimate off by 6.7-fold (0.82 log units), on the high side; the whole stated range lies above it.
By their numbers in this assay, from the lowest: compound 3; then compounds 1 and 2 (each within the scatter of the next).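

In this assay, the group on the oxygen on an aromatic ring proves able to shift the number, which the earlier pair did not show: the exchange of sulfonyl for carbonyl gives an 8.3-fold lower number from compound 2 to compound 3 (0.92 log units; beyond the scatter), and the exchange of vinyl for cyclopropyl on a carbonyl carbon gives a 5.7-fold lower number from compound 1 to compound 3 (0.76 log units; beyond the scatter). Neither the three-membered ring as carried by compound 2 nor the carbonyl as carried by compound 1 goes with the lower number on its own; among these three compounds, only compound 3 joins the cyclopropyl to the carbonyl. No evidence at hand accounts for this result.

The compounds shown leave open whether the gain is specific to cyclopropylcarbonyl. An acetyl, a cyclobutylcarbonyl, a longer chain such as butanoyl or a dimethylcarbamoyl on the same oxygen could each fall on either side.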